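A few compounds are considered here, and "the series" means these few. Any claim that something is new, unique, unknown or untested is made for them only; others in the source may bear on it.

Compound 3 `O=c1ccoc2cc(OCc3cn(Cc4ccc(F)cc4)nn3)ccc12` stands at the limit in a functional assay on SGC-7901 cells (Homo sapiens) for cytotoxicity, read by MTT assay, with a stated time of 48 h (a higher number here means a weaker inhibitor, a lower number a stronger inhibitor), where compound 3 gives > 100000 nM, a limit of the assay rather than a number. Compound 1 `O=c1ccoc2cc(OCc3cn(Cc4ccccc4)nn3)ccc12` also gives only a limit in this assay, > 100000 nM. Compound 2 `O=c1ccoc2cc(OCc3cn(Cc4cccc(Br)c4)nn3)ccc12` gives > 100000 nM, again a limit. With the limit of > 100000 nM in this assay, at which 3 of the 3 values shown sit, every step among the three is unreadable: a step that the two limits leave unreadable from compound 1 to compound 2, a step that the two limits leave unreadable from compound 1 to compound 3 and a step that the two limits leave unreadable from compound 2 to compound 3. Compound 4 `O=c1ccoc2cc(OCc3cn(Cc4ccc(Br)cc4)nn3)ccc12` differs from compound 3 by bromo in place of fluoro on an aromatic carbon. Among the measured compounds shown here, no measured step with a readable size bears on this change; the steps that put bromo or fluoro in place of hydrogen all end at the limit. Compound 4 is therefore expected to remain at the limit as well, the estimated step being a step that the limit leaves unreadable from compound 3 to compound 4. The estimate for compound 4 is 150000 nM, with a range from 60000 nM to 400000 nM.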

Compound 4, half-maximal inhibitory concentration: > 100000 nM
Compound 4: no number, only a limit; the forecaster's own chance of this, stated with the estimate: 85%; the middle value is on the limit's open side.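

Compound 4 sits at a limit like compound 1, compound 2 and compound 3, so no step among them can be read: the limit of > 100000 nM in this assay, at which 4 of the 4 values shown sit.
The compounds shown leave open whether any change to this series would give a readable value in this assay at all.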